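This account rests on a few compounds, and the source may have more. Where it says the series, first, only, none or still open, it means among the compounds named here.

Measured so far in a functional assay on Ehrlich cells (Mus musculus) for cytotoxicity, read by trypan blue exclusion, with a stated time of 2 h, tested at 10 ug/mL; a higher number here means a weaker effect of the compound at the concentration tested, a lower number a stronger effect:

Compound 2 `Cc1c(NC(=O)OC(C)C)[n+]([O-])c2cc(Cl)ccc2[n+]1[O-]`: 97.3%
Compound 1 `COc1ccc2c(c1)[n+]([O-])c(C(=O)N=[N+]=[N-])c(C)[n+]2[O-]`: 58.3%

In this assay compound 2 gives 97.3%, the highest of the two numbers, while compound 1 gives 58.3%, lower by more than the usual scatter. Compound 3 `COc1ccc2c(c1)[n+]([O-])c(NC(=O)OC(C)C)c(C)[n+]2[O-]` has not yet been measured. It differs from compound 2 in a single place: methoxy in place of chloro on an aromatic carbon. For the measured compounds named here, no measured pair shows this change on its own. A modest step toward a stronger effect is expected, of a size near the edge of the scatter. The step expected is a number 12.3 percentage points lower from compound 2 to compound 3 (beyond the scatter). Compound 3 is estimated at 85%, within a range from 55% to 100%.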

Compound 3, a percentage reported as activity, at one concentration (the size of the read-out at that concentration, not a potency): 90.4%
Compound 3: the middle estimate sits 5.4 percentage points below what was measured; the measured number falls inside the stated range.
By their numbers in this assay, from the lowest: compound 1; then compounds 3 and 2 (each within the scatter of the next).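

In this assay, the swap of methoxy in place of chloro on an aromatic carbon gives a number 6.9 percentage points lower from compound 2 to compound 3 (within the scatter), so the two groups cannot be told apart at this position. The other place on the shared core matters more: the group of 7 heavy atoms in place of the group of 5 heavy atoms gives a number 32.1 percentage points higher from compound 1 to compound 3 (beyond the scatter). No measurement here accounts for either step.

As far as these compounds go, whether an amine or a carboxylic acid at the chloro position would move the read-out remains open. These numbers also speak only of a stronger or weaker effect at the one concentration tested.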